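Working notes on a small agonist series

The source may hold more compounds than are shown below. What is called first, only, known or untested is meant among the compounds shown, and "the series" means these compounds.

Measured so far:
compound 1, `Cc1cccc(NC(=O)CN2CCC(c3cccc(C#N)n3)CC2)c1`, 42%
compound 2, `O=C(NCN1CCC(c2cccc[n+]2[O-])CC1)c1ccc2ccccc2c1`, 67%
compound 3, `Cc1cccc(C(=O)NCN2CCC(c3cccc[n+]3[O-])CC2)c1`, 77%

In a functional assay on HEK293 cells for agonist activity at D(4) dopamine receptor (Homo sapiens), read by FLIPR (on this read-out higher numbers stand for larger maximal responses and lower numbers for smaller maximal responses), compound 1 gives 42%, the lowest of the three numbers. Compound 2 sits higher by a margin beyond the scatter, and compound 3 stands further above still, also beyond the scatter. Among the compounds with values here, both compound 2 and compound 3 differ from compound 1 in more than one place, so no single-point step among the measured compounds is available. Compound 4, `Cc1cccc(NC(=O)CN2CCC(c3cccc(F)c3)CC2)c1`, differs from compound 1 in one place: 3-fluorophenyl in place of 6-cyanopyridin-2-yl on a saturated ring carbon. Within the data shown here, no measured pair tells what this exchange does on this read-out. The step of a number 3 percentage points higher from compound 1 to compound 4 (within the scatter) is expected to be small, without a firm direction, and may well fall within the scatter. Compound 4 is estimated at 45%, between 20% and 75%.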

Compound 4, largest response reached (reported as efficacy), in percent of the reference or control that the assay uses: 40%
Compound 4: the middle estimate sits 5 percentage points above what was measured; the measured number falls inside the stated range.
By their numbers in this assay, from the lowest: compounds 4 and 1 (each within the scatter of the next); then compounds 2 and 3 (each within the scatter of the next).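

In this assay placing 3-fluorophenyl in place of 6-cyanopyridin-2-yl on the saturated ring carbon gives a number 2 percentage points lower from compound 1 to compound 4 (within the scatter) and so leaves the maximal response unresolved between the two groups. On this core, the response therefore survives loss of the nitrile and the pyridine ring nitrogen, and the count of hydrogen-bond acceptors in this group can go from 2 to 0 without a step beyond the scatter. No available data bear on why the two groups match.

Going by these compounds, whether an aminomethyl group or a carboxylic acid on this ring carbon would shift the response remains open. Also open, on these data alone, is whether this exchange would give a similar step on another amide arrangement.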